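Cytotoxicity notes on the oxazolidinone series, step to compound 4

The source may report more compounds than this note shows. Statements on the series, on what has been measured and on what is new or still open speak of the compounds shown alone.

Compound 1 `CN(CCC#N)C[C@H]1CN(c2ccc(-n3cc(-c4ccccn4)cn3)c(F)c2)C(=O)O1`: in an ADME assay on L02 cells (Homo sapiens) for cytotoxicity, read by MTT assay, with a stated time of 48 h (a higher number here means a weaker inhibitor, a lower number a stronger inhibitor), compound 1 gives > 400 ug/mL, a limit of the assay.
Compound 2 `O=C1O[C@@H](CN2CCC(O)CC2)CN1c1ccc(-n2cc(-c3ccccn3)cn2)c(F)c1`: in this assay compound 2 gives > 400 ug/mL, likewise a limit.
Compound 3 `O=C(OC[C@H]1CN(c2ccc(-n3cc(-c4ccccn4)cn3)c(F)c2)C(=O)O1)c1ccccc1`: in this assay compound 3 gives > 400 ug/mL, again a limit.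

Compound 3 therefore stands where every other measured compound stands: at the limit of the assay, and no number separates it from the rest. The three measured steps, a step that the two limits leave unreadable from compound 1 to compound 2, a step that the two limits leave unreadable from compound 1 to compound 3 and a step that the two limits leave unreadable from compound 2 to compound 3, all stay unreadable, because of the limit of > 400 ug/mL in this assay, at which 3 of the 3 values shown sit.

Compound 4 `O=CNC[C@H]1CN(c2ccc(-n3cc(-c4ccccn4)cn3)c(F)c2)C(=O)O1` is the unmeasured member. The change from compound 3 is formylamino in place of benzoyloxy on a saturated chain carbon bound to a saturated ring carbon. Each earlier swap at that same saturated chain carbon left the value at the limit, so no step beyond the scatter is expected from compound 3 to compound 4 in this assay; the expected step is a number no higher from compound 3 to compound 4 (the limit leaves the size open). For compound 4 the estimated value is 400 ug/mL, with a range from 150 ug/mL to 800 ug/mL, and most likely the assay again reports only a limit.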

Compound 4, half-maximal inhibitory concentration: > 400 ug/mL
Compound 4 was reported as a limit; the forecaster's own chance of this, stated with the estimate: 85%; the middle value lies on the limit itself.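

For the compounds shown here, compound 4 stands at the limit with compound 1, compound 2 and compound 3 in this assay, so no step to compound 4 can be read: the limit of > 400 ug/mL in this assay, at which 4 of the 4 values shown sit.

The compounds shown leave open whether any group on that saturated chain carbon changes the read-out at all, and by how much.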